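The source may report more compounds than this note shows. Statements on the series, on what has been measured and on what is new or still open speak of the compounds shown alone.

Compound 1 `COc1cc(-c2ccnc3cc(-c4ccc5cc[nH]c5c4)nn23)cc(OC)c1OC` gives 125 nM in a functional assay on HeLa cells (Homo sapiens) for inhibition, read by CCK-8 assay, with a stated time of 48 h; on this read-out higher numbers stand for weaker inhibition and lower numbers for stronger inhibition.
Compound 2 `COc1cc(-c2ccnc3cc(-c4ccc(C(C)(C)C)cc4)nn23)cc(OC)c1OC` reaches only the limit > 10000 nM in this assay.
Compound 3 `COc1cc(-c2ccnc3cc(-c4cccc(C#N)c4)nn23)cc(OC)c1OC` likewise stops at the limit > 10000 nM in this assay.

Among the compounds with values here, compound 1 holds the only real number of the three; the other two values are limits, (the limit of > 10000 nM in this assay, at which 2 of the 3 values shown sit). Compound 4 `COc1cc(-c2ccnc3cc(-c4ccc(C(F)(F)F)cc4)nn23)cc(OC)c1OC` has not been measured. It differs from compound 1 in one place: 4-(trifluoromethyl)phenyl in place of 1H-indol-6-yl on an aromatic carbon. Two measured steps start from the same point and swap the same group for a plain phenyl ring carrying one substituent: an at least 80-fold higher number from compound 1 to compound 2 (1.90 log units; beyond the scatter) and an at least 80-fold higher number from compound 1 to compound 3 (1.90 log units; beyond the scatter). Both are large rises. A rise of similar size is therefore expected here. Compound 4 is expected to give about 12000 nM, estimated between 3000 nM and 40000 nM. That estimate means an expected step of a 96-fold higher number from compound 1 to compound 4 (1.98 log units; beyond the scatter).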

Compound 4, half-maximal inhibitory concentration: 1840 nM
Compound 4: the middle estimate sits 6.5-fold (0.81 log units) above what was measured; measured number below the stated range.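

In this assay, replacing 1H-indol-6-yl with a singly substituted phenyl ring need not push the value to the limit: a 15-fold higher number from compound 1 to compound 4 (1.17 log units; beyond the scatter), a large loss that still gives a real number. The substituent on that phenyl ring also matters, with an at least 5.4-fold lower number from compound 3 to compound 4 (0.73 log units; beyond the scatter) and an at least 5.4-fold lower number from compound 2 to compound 4 (0.73 log units; beyond the scatter). These last two steps give only minimum sizes: the limit of > 10000 nM in this assay, at which 2 of the 4 values shown sit.

The compounds shown do not separate the part played by the hydrogen-bond donor of 1H-indol-6-yl from that of its second ring. On these data alone, how a phenyl ring carrying an amine or a carboxylic acid would compare also remains open.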